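Aryl swap on the triazole: outlook for compound 4

The source may hold more compounds than are shown below. What is called first, only, known or untested is meant among the compounds shown, and "the series" means these compounds.

Of the compounds shown here, three on the shared core have been measured. Compound 1 `N#CC1=C(N)Oc2c(N)cc3nc4ccccc4nc3c2C12C(=O)N(Cc1cnnn1-c1ccccc1Br)c1ccccc12` gives 38000 nM in a functional assay on HepG2 cells (Homo sapiens) for antiproliferative activity, read by MTT assay, with a stated time of 48 h; a lower number here means a stronger inhibitor, a higher number a weaker inhibitor. Compound 2 `N#CC1=C(N)Oc2c(N)cc3nc4ccccc4nc3c2C12C(=O)N(Cc1cnnn1-c1cccc(C(F)(F)F)c1)c1ccccc12` gives 15800 nM in this assay, and the step of a 2.4-fold lower number from compound 1 to compound 2 (0.38 log units; beyond the scatter) is the only one beyond the scatter so far. Compound 3 `CCOc1ccccc1-n1nncc1CN1C(=O)C2(C(C#N)=C(N)Oc3c(N)cc4nc5ccccc5nc4c32)c2ccccc21` gives 30500 nM in this assay, the second highest of the three numbers. The steps of a 1.2-fold lower number from compound 1 to compound 3 (0.10 log units; within the scatter) and a 1.9-fold higher number from compound 2 to compound 3 (0.29 log units; within the scatter) both stay within the scatter, so no order among these three can be claimed apart from the gap between compound 1 and compound 2.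

Compound 4 `N#CC1=C(N)Oc2c(N)cc3nc4ccccc4nc3c2C12C(=O)N(Cc1cnnn1-c1ccc(Cl)cc1Cl)c1ccccc12` is not yet measured. Its change from compound 3 is 2,4-dichlorophenyl in place of 2-ethoxyphenyl on an aromatic nitrogen. The step bearing most directly on it is a 1.2-fold lower number from compound 1 to compound 3 (0.10 log units; within the scatter), where a halogen gave way to ethoxy without a shift beyond the scatter; the reverse direction, back toward halogen substitution, is therefore expected to move little. The step of a 2.4-fold lower number from compound 1 to compound 2 (0.38 log units; beyond the scatter) was modest, and nothing in the set suggests a larger effect here.

Compound 4 is expected at 25000 nM, with a range of 10000 nM to 60000 nM. The expected step of a 1.2-fold lower number from compound 3 to compound 4 (0.09 log units; within the scatter) lies within the scatter.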

Compound 4, half-maximal inhibitory concentration: > 50000 nM
Compound 4: a limit, no number; the forecaster's own chance of this, stated with the estimate: 5%; middle value at least 2.0-fold (0.30 log units) away from the limit.
By their numbers in this assay, from the lowest: compounds 2, 3 and 1 (each within the scatter of the next, the first and the last beyond it). At a limit, above all of these: compound 4.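

In this assay compound 4 gives a limit and not a number: the limit of > 50000 nM in this assay, at which 1 of the 4 values shown sits. At this position on the five-membered aromatic ring with 3 nitrogen, a second aryl swap now reaches beyond the scatter, an at least 3.1-fold higher number from compound 2 to compound 4 (0.50 log units; beyond the scatter), and compound 2 is the low end of both such gaps. The floors of an at least 1.6-fold higher number from compound 3 to compound 4 (0.21 log units; that floor lies within the scatter) and an at least 1.3-fold higher number from compound 1 to compound 4 (0.11 log units; that floor lies within the scatter) lie within the scatter, so those two gaps remain unsized.

The aryl groups shown carry only halogen, trifluoromethyl or ethoxy, so the response to an aryl group bearing an amine or a carboxylic acid remains open. Also open, from the compounds shown here alone, is whether any group at this position gives a number clearly lower than that of compound 2, such as a longer alkyl chain in place of the aryl ring.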